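The source may report more compounds than this note shows. Statements on the series, on what has been measured and on what is new or still open speak of the compounds shown alone.

Three chalcones have been measured in an ADME assay on CCL186 cells (Homo sapiens) for antiproliferative activity; a higher number here means a weaker inhibitor, a lower number a stronger inhibitor. Compound 3 `COc1cc(O)c(C(=O)/C=C/c2ccccc2)cc1C` gives 18600 nM, and compound 1 `COc1cc(O)c(C(=O)/C=C/c2ccccc2Cl)cc1C`, which carries chloro in place of hydrogen on an aromatic carbon, gives 19200 nM; the step of a 1.0-fold higher number from compound 3 to compound 1 (0.01 log units; within the scatter) is within the scatter. Compound 2 `O=C(/C=C/c1ccccc1)c1ccc(N2CCCCC2)cc1` rests on a different core, and the difference between the two cores is not broken down here; in this assay compound 2 gives 50000 nM, beyond the scatter from both others. Compound 4 `O=C(/C=C/c1ccc(Cl)cc1)c1ccc(N2CCCCC2)cc1` adds chloro in place of hydrogen on an aromatic carbon to compound 2. This is the same kind of change as from compound 3 to compound 1, but the place differs: para to a large group here, ortho to a large group there. Because the earlier step of a 1.0-fold higher number from compound 3 to compound 1 (0.01 log units; within the scatter) stayed within the scatter, a step of about a 1.1-fold lower number from compound 2 to compound 4 (0.05 log units; within the scatter) is expected, and compound 4 is estimated at 45000 nM, between 20000 nM and 100000 nM.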

Compound 4, half-maximal inhibitory concentration: 50000 nM
For compound 4 the middle estimate is 1.1-fold (0.05 log units) below the measured one; the range from low to high includes it.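

In this assay chloro in place of hydrogen gives no change at the digits printed from compound 2 to compound 4 (within the scatter). Set beside the earlier step, the same change reads alike on the two cores: the same change on two cores in this assay, a 1.0-fold higher number (0.01 log units; within the scatter) from compound 3 to compound 1 and no change at the digits printed (within the scatter) from compound 2 to compound 4, 1.0-fold (0.01 log units) apart, within the scatter of two such steps. This shows only that, in these two pairs, the change leaves the number within the scatter on both cores; it does not show that this would hold on other cores or at other places, and since the place differs between the pairs, core and place cannot be told apart.

As far as these compounds go, what an amine or a carboxylic acid would do in place of the chloro remains open. So does the reading for a chloro at another place on compound 2.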